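The source may hold more compounds than are shown below. What is called first, only, known or untested is meant among the compounds shown, and "the series" means these compounds.

Working notes on the series. The shared core carries a 4-halophenyl or 4-methylphenyl group on one side and an acetamide chain on the other. Compound 1 `NC(=O)Cn1c(-c2ccc(Br)cc2)nc2cccnc21` gives 17.8 mg/kg in a functional assay on the whole organism with Mus musculus as the target; a higher number here means that more compound is needed for the effect, a lower number that less compound is needed. For the measured compounds named here, compound 2 `Cc1ccc(-c2nc3cccnc3n2CC(N)=O)cc1` gives 50.5 mg/kg in this assay, and the single one-place step recorded so far, a 2.8-fold higher number from compound 1 to compound 2 (0.45 log units; beyond the scatter), lies beyond the scatter. Compound 3 `CNC(=O)Cn1c(-c2ccc(Cl)cc2)nc2cccnc21` gives 12.5 mg/kg in this assay, the lowest of the three numbers; it sits within the scatter of compound 1 and beyond the scatter of compound 2, so it cannot be called the most active on these data.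

Compound 4 `CN(C)CCN(C)C(=O)Cn1c(-c2ccc(Cl)cc2)nc2cccnc21` is not yet measured. It differs from compound 3 by 2-(dimethylamino)ethyl in place of hydrogen on an amide-type nitrogen. Going by the values given here, no measured step touches this amide-type nitrogen: the only recorded step changes a group on the aromatic carbon, and compounds 1 and 3 differ in two places, so their values can only be said to lie within the scatter of each other. Among the compounds with values here, the structural change to compound 4 therefore has no precedent, and the step of a 1.2-fold higher number from compound 3 to compound 4 (0.08 log units; within the scatter) is expected to stay within the scatter, in either direction. Compound 4 is estimated at 15 mg/kg in this assay, within a range of 6 mg/kg to 40 mg/kg.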

Compound 4, dose for half-maximal effect: 100 mg/kg
For compound 4 the middle estimate is 6.7-fold (0.82 log units) below the measured one; the whole stated range lies below it.
By their numbers in this assay, from the lowest: compounds 3 and 1 (each within the scatter of the next); then compounds 2 and 4 (each within the scatter of the next).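

The amide-type nitrogen of compound 3, whose other neighbours are the carbonyl carbon and a saturated chain carbon, now has its first measured step: 2-(dimethylamino)ethyl in place of hydrogen gives an 8.0-fold higher number from compound 3 to compound 4 (0.90 log units; beyond the scatter) in this assay and so moves the number beyond the scatter. The earlier step on the aromatic carbon could not speak to this nitrogen, whereas this result shows that the position does not tolerate every change without a shift, at least with this chain on the chloro-substituted compound. Nothing on hand bears on the reason for the step, which stands here as an observation only.

The compounds shown leave open whether the higher number follows from the loss of the amide hydrogen as such or from the chain that replaces it, since both come together in this one step. A second methyl on this nitrogen, an ethyl or a 2-hydroxyethyl chain, or a longer chain ending in a dimethylamino group or a carboxylic acid would be needed to separate these readings.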